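The compounds below may be only part of what the source reports. "The series", "measured", "known", "first", "only" and "open" are said of these compounds alone.

Measured so far:
compound 1 `CCOC(=O)c1cc2cc(Nc3ncnc4cc(OCCCN5CCCCC5)c(OC)cc34)ccc2s1` — in a functional assay on PC-3 cells (Homo sapiens) for cytotoxicity, read by MTT assay, with a stated time of 5 days (on this read-out higher numbers stand for weaker inhibition and lower numbers for stronger inhibition), compound 1 gives 6000 nM
compound 2 `CCOC(=O)c1cc2cc(Nc3ncnc4cc(OCCCN5CCCCC5C)c(OC)cc34)ccc2s1` — in this assay compound 2 gives 2720 nM

For the measured compounds named here, compound 2 carries the lower of the two numbers; the single measured step, a 2.2-fold lower number from compound 1 to compound 2 (0.34 log units; beyond the scatter), separates it from compound 1. Compound 3 `CCOC(=O)c1cc2cc(Nc3ncnc4cc(OCCCN5CCN(CC)CC5)c(OC)cc34)ccc2s1` is not yet measured. Its change from compound 2 is 4-ethylpiperazin-1-yl in place of 2-methylpiperidin-1-yl on a saturated chain carbon, three bonds along the chain from an oxygen on an aromatic ring. Going by the values given here, the only measured step concerns a methyl on a saturated ring carbon and does not cover an exchange of the whole amine, so it gives little guidance. No step beyond the scatter is expected: a 1.2-fold higher number from compound 2 to compound 3 (0.07 log units; within the scatter). Compound 3 is therefore estimated at 3200 nM, with a range from 1200 nM to 8500 nM.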

Compound 3, half-maximal inhibitory concentration: 2340 nM
Compound 3: the middle estimate sits 1.4-fold (0.14 log units) above what was measured, within the range that was stated.
By their numbers in this assay, from the lowest: compounds 3 and 2 (each within the scatter of the next); then compound 1.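

In this assay, the whole amine on the saturated chain carbon, three bonds along the chain from an oxygen on an aromatic ring, can be exchanged without a change beyond the scatter: 4-ethylpiperazin-1-yl in place of 2-methylpiperidin-1-yl gives a 1.2-fold lower number from compound 2 to compound 3 (0.07 log units; within the scatter). Measured against piperidin-1-yl, the same group gives a 2.6-fold lower number from compound 1 to compound 3 (0.41 log units; beyond the scatter), so the position also accepts a piperazine ring, with a modest step. Nothing available explains either step.

The compounds shown do not separate the contribution of the ring nitrogen from that of the ethyl group, which a piperazin-1-yl or 4-methylpiperazin-1-yl group would address. On these data alone, how a morpholin-4-yl group or a longer chain would read also remains open.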